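Changing the aryl group on the ring nitrogen

A few compounds are considered here, and "the series" means these few. Any claim that something is new, unique, unknown or untested is made for them only; others in the source may bear on it.

Of the compounds shown here, three built on one shared core have been measured in a functional assay on the whole organism (strain Swiss albino) for inhibition, with Mus musculus as the target, with a stated time of 4 h; on this read-out higher numbers stand for an effect only at larger amounts of compound and lower numbers for an effect already at smaller amounts. Compound 1 `COc1ccccc1-n1c(Nc2nc(-c3ccc([N+](=O)[O-])cc3)cs2)n[nH]c1=S` gives 100 mg/kg. Compound 2 `COc1ccccc1-n1c(Nc2nc(-c3ccccc3)cs2)n[nH]c1=S` gives 300 mg/kg. Compound 3 `COc1ccccc1-n1c(Nc2nc(-c3ccc(Br)cc3)cs2)n[nH]c1=S` gives 300 mg/kg. Among the measured compounds shown here, on these numbers compound 3 stands level with compound 2, the pair sharing the top of the set, and its only step beyond the scatter is a 3.0-fold higher number from compound 1 to compound 3 (0.48 log units; beyond the scatter). The two steps away from compound 1 are alike in size: a 3.0-fold higher number from compound 1 to compound 2 (0.48 log units; beyond the scatter) and a 3.0-fold higher number from compound 1 to compound 3 (0.48 log units; beyond the scatter). Between the other two, no change at the digits printed from compound 2 to compound 3 (within the scatter).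

Compound 4 `Cc1ccc(-n2c(Nc3nc(-c4ccc(Br)cc4)cs3)n[nH]c2=S)cc1` differs from compound 3 in a single place: 4-methylphenyl in place of 2-methoxyphenyl on an aromatic nitrogen. None of the three measured steps bears directly on this change, since each of them alters a group on a different part of the molecule and leaves the group on the aromatic nitrogen of the five-membered aromatic ring with 3 nitrogen untouched. For the measured compounds named here, with no step of this kind to draw on, the best expectation is that compound 4 stays close to compound 3, giving an expected step of no change at the digits printed from compound 3 to compound 4 (within the scatter). Compound 4 is therefore estimated at 300 mg/kg, with a range from 100 mg/kg to 1000 mg/kg.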

Compound 4, minimum effective dose: 300 mg/kg
Beside the measured number, compound 4's estimate shows no gap at the digits printed; measured number inside the range.
By their numbers in this assay, from the lowest: compound 1; then compounds 2, 3 and 4 (each within the scatter of the next).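

Swapping the aryl group on the aromatic nitrogen of the five-membered ring gives no change at the digits printed from compound 3 to compound 4 (within the scatter) in this assay, so this is the first sign that this position can change without moving the minimum effective dose, at least when the bromo group stays in place. The group that leaves holds an oxygen and a hydrogen-bond acceptor while the group that enters holds neither, yet this single pair shows no measurable cost from that exchange, although the substituent on the phenyl ring and its place both differ, so their separate contributions stay tangled. No measurement at hand gives a reason for this flat result.

From the compounds shown here alone, what stays open is whether the same swap would also leave the number unmoved on the nitro compound, compound 1, which alone sits apart from the others in this set. Going by these compounds, it is equally open how far this tolerance reaches, for instance with an aminophenyl or carboxyphenyl group on that nitrogen, or with a simple alkyl chain in place of the aryl ring.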